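Extending the side chain of compound 2

This account rests on a few compounds, and the source may have more. Where it says the series, first, only, none or still open, it means among the compounds named here.

- compound 1 (`Cc1cn(C2OC(CO[Si](C)(C)C(C)(C)C)C3(OS(=O)(=O)C=C3N)C2O[Si](C)(C)C(C)(C)C)c(=O)n(CCCNC(=O)[C@@H]2CCCN2C(=O)[C@@H](N)C(C)C)c1=O`): 10000 nM
- compound 2 (`Cc1cn(C2OC(CO[Si](C)(C)C(C)(C)C)C3(OS(=O)(=O)C=C3N)C2O[Si](C)(C)C(C)(C)C)c(=O)n(CCCNC(=O)[C@@H]2CCCN2C(=O)[C@H](C)N)c1=O`): 19000 nM

In a functional assay on CCRF-CEM cells (Homo sapiens) for antiproliferative activity (on this read-out higher numbers stand for lower toxicity in this test and lower numbers for higher toxicity in this test), compound 2 gives 19000 nM, a number within the usual scatter of compound 1 at 10000 nM, so the two cannot be ranked. Compound 3 (`Cc1cn(C2OC(CO[Si](C)(C)C(C)(C)C)C3(OS(=O)(=O)C=C3N)C2O[Si](C)(C)C(C)(C)C)c(=O)n(CCCNC(=O)[C@@H]2CCCN2C(=O)[C@@H](N)CCCCN)c1=O`) differs from compound 2 by 3-aminopropyl in place of hydrogen on a saturated chain carbon, two bonds along the chain from an amine nitrogen and a carbonyl carbon, which is 3-aminopropyl in place of hydrogen on a saturated chain carbon, two bonds along the chain from an amine nitrogen and a carbonyl carbon. Going by the values given here, only one measured step bears on this: methyl in place of isopropyl, a 1.9-fold higher number from compound 1 to compound 2 (0.28 log units; within the scatter). That step stayed within the scatter, but it involved no amine-bearing group, so it is a thin guide. No step beyond the scatter is therefore expected in this assay. The expected change is a 1.4-fold lower number from compound 2 to compound 3 (0.13 log units; within the scatter). For compound 3 the estimate is 14000 nM, with an expected range of 6000 nM to 35000 nM.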

Compound 3, half-maximal cytotoxic concentration: 47000 nM
Estimate against measurement, compound 3: 3.4-fold (0.53 log units) below; the whole stated range lies below it.
By their numbers in this assay, from the lowest: compounds 1 and 2 (each within the scatter of the next); then compound 3.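

In this assay this position does respond to a change of side chain: 3-aminopropyl in place of hydrogen gives a 2.5-fold higher number from compound 2 to compound 3 (0.39 log units; beyond the scatter), a modest move towards lower toxicity, whereas methyl in place of isopropyl stayed within the scatter. Against the isopropyl compound, 4-aminobutyl gives a 4.7-fold higher number from compound 1 to compound 3 (0.67 log units; beyond the scatter), also modest and in the same direction, so compound 3 stands apart from compound 1 and compound 2, which cannot be ranked against each other. Nothing measured here accounts for this shift.

Going by these compounds, it remains open whether the shift goes with the amine or with the length of the chain, and a plain butyl chain carrying no amine would separate the two. A carboxylic acid at the end of the chain would show whether another end group moves the number in the same direction.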